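A few compounds are considered here, and "the series" means these few. Any claim that something is new, unique, unknown or untested is made for them only; others in the source may bear on it.

Compound 1 `CCOC(=O)c1cc(-c2cc(OC)c(OC)c(OC)c2)c(-c2ccc(OC)c([N+](=O)[O-])c2)s1` and compound 3 `COc1ccc(-c2cc(C(=O)O)sc2-c2cc(OC)c(OC)c(OC)c2)cc1[N+](=O)[O-]` share most of their structure but differ in their cores, and the difference between the two cores is not broken down here. In a functional assay on SGC-7901 cells (Homo sapiens) for antiproliferative activity, read by MTT assay, with a stated time of 72 h (on this read-out lower numbers stand for stronger inhibition and higher numbers for weaker inhibition), compound 1 gives 18100 nM. In the same assay compound 3 gives 21600 nM, a number that lies within the usual scatter of the value for compound 1, so no order between the two is claimed.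

Compound 2 `CCOC(=O)c1cc(-c2cc(OC)c(OC)c(OC)c2)c(-c2ccc(OC)c(OCc3ccccc3)c2)s1` arises from compound 1 by a single change, (benzyloxy in place of nitro on an aromatic carbon). In this assay compound 2 gives > 100000 nM, which is a limit of the assay rather than a number, as shown by the limit of > 100000 nM in this assay, at which 1 of the 3 values shown sits. The change thus produced an at least 5.5-fold higher number from compound 1 to compound 2 (0.74 log units; beyond the scatter).

Compound 4 `COc1ccc(-c2cc(C(=O)O)sc2-c2cc(OC)c(OC)c(OC)c2)cc1OCc1ccccc1` is the corresponding analogue of compound 3. The change from compound 3 to compound 4 is benzyloxy in place of nitro on an aromatic carbon, the same change at the same place, described in the same words as before. Because the earlier step from compound 1 to compound 2 was an at least 5.5-fold higher number from compound 1 to compound 2 (0.74 log units; beyond the scatter), and because compound 3 already gives 21600 nM, the same change is expected to carry compound 4 to a markedly higher number as well. The step from compound 3 to compound 4 is therefore estimated as a 5.6-fold higher number from compound 3 to compound 4 (0.74 log units; beyond the scatter) in this assay. Compound 4 is estimated at 120000 nM, within a range from 50000 nM to 300000 nM.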

Compound 4, half-maximal inhibitory concentration: > 100000 nM
Compound 4 was reported as a limit (the forecaster's own chance of this, stated with the estimate: 65%); the middle value lies beyond the limit too.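

In this assay compound 4 gives > 100000 nM, which is a limit of the assay and not a number. Benzyloxy in place of nitro on an aromatic carbon therefore gives an at least 4.6-fold higher number from compound 3 to compound 4 (0.66 log units; beyond the scatter), so the direction seen on the core of the ester recurs on the core of the acid, and on both cores the shift lies beyond the scatter: the same change on two cores in this assay, an at least 5.5-fold higher number (0.74 log units; beyond the scatter) from compound 1 to compound 2 and an at least 4.6-fold higher number (0.66 log units; beyond the scatter) from compound 3 to compound 4; the limit leaves it open whether they differ. Among these compounds, this does not show how large either step really is, nor whether one core responds more strongly than the other, and it rests on a single change carried across only two cores, since both benzyloxy compounds stop at the same limit: the limit of > 100000 nM in this assay, at which 2 of the 4 values shown sit.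

The compounds shown leave open what an amine, a hydroxyl or a fluorine would do at this place on either core, and whether such replacements would give actual numbers rather than limits, so that the two cores could be compared in size as well as in direction. They also leave open whether the same change would hold on a third core, for example one carrying an amide where these compounds carry the ester or the acid.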